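A few compounds are considered here, and "the series" means these few. Any claim that something is new, unique, unknown or untested is made for them only; others in the source may bear on it.

In a functional assay on HCT-116 cells (Homo sapiens) for antiproliferative activity, read by radiometric assay, with a stated time of 72 h (a higher number here means a weaker inhibitor, a lower number a stronger inhibitor), compound 1 (`Cc1cc(F)ccc1Nc1ncnc2cc(NC(=O)CCCCCCC(=O)NO)sc12`) gives 2640 nM and compound 2 (`O=C(CCCCCCC(=O)Nc1cc2ncnc(Nc3ccc(Cl)cc3F)c2s1)NO`) gives 1790 nM. The two share a core and differ only in the ring group on a nitrogen. Within the data shown here, the single measured step, a 1.5-fold lower number from compound 1 to compound 2 (0.17 log units; within the scatter), lies within the scatter, so the two numbers cannot be told apart and compound 2 holds no real rank.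

Compound 3 (`Cc1ccc(F)c(Nc2ncnc3cc(NC(=O)CCCCCCC(=O)NO)sc23)c1`) has not yet been measured. It keeps the same core and carries 2-fluoro-5-methylphenyl in place of 4-chloro-2-fluorophenyl on a nitrogen on an aromatic ring. Among the measured compounds shown here, the new group is named with the same two substituents as the 4-fluoro-2-methylphenyl of compound 1, so that one step is the only evidence that bears on this change. Compound 2 differs from compound 1 by a swap at this same place, and that swap gave only a 1.5-fold lower number from compound 1 to compound 2 (0.17 log units; within the scatter). For the measured compounds named here, no measured compound carries the new group itself, so the evidence is thin and the range should stay wide.

The expected change, a 1.2-fold higher number from compound 2 to compound 3 (0.09 log units; within the scatter), is an estimate and is not expected to exceed the scatter. For compound 3 the estimated value is 2200 nM, with an expected range from 1100 nM to 4500 nM.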

Compound 3, half-maximal inhibitory concentration: 1330 nM
The estimate for compound 3 lay 1.7-fold (0.22 log units) above the measured number; measured number inside the range.
By their numbers in this assay, from the lowest: compounds 3, 2 and 1 (each within the scatter of the next).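

In this assay, 2-fluoro-5-methylphenyl in place of 4-chloro-2-fluorophenyl gives a 1.3-fold lower number from compound 2 to compound 3 (0.13 log units; within the scatter), and the same group in place of 4-fluoro-2-methylphenyl gives a 2.0-fold lower number from compound 1 to compound 3 (0.30 log units; within the scatter). Among these compounds, both steps lie within the scatter, as did the one earlier step at this place, so all three ring groups on this nitrogen read alike, including a pair that carries fluoro and methyl substituents at different ring positions and a pair that differs in having chloro or methyl. The data offer no measured explanation for this similarity.

These three groups are all phenyl rings carrying two small substituents, so the compounds shown leave open whether the number would stay in this range with a quite different group on the nitrogen, such as a phenyl ring bearing an amine or a carboxylic acid, or a pyridine ring. The core and the chain ending in the hydroxamic acid are also the same in all three compounds, so the effect of a shorter or longer chain at that other place remains an open question.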